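The compounds below may be only part of what the source reports. "The series", "measured", "known", "first", "only" and "open" are said of these compounds alone.

Compound 1 `O=S(=O)(Nc1ccc(-c2nc3cc(NS(=O)(=O)c4ccccc4O)ccc3o2)cc1)c1ccccc1O`: 18000 nM
Compound 2 `Cc1ccc(S(=O)(=O)Nc2ccc(-c3nc4ccccc4o3)cc2)cc1`: > 100000 nM, a limit of the assay, not a number.
Compound 3 `COc1cccc(S(=O)(=O)Nc2ccc3oc(-c4ccccc4)nc3c2)c1`: > 100000 nM, likewise a limit.

In an assay on cells for inhibition of HSP60/HSP10 (Homo sapiens), with a stated time of 60 min (on this read-out lower numbers stand for stronger inhibition and higher numbers for weaker inhibition), compound 1 gives 18000 nM. Compound 2 sits at the limit of > 100000 nM in this assay, at which 2 of the 3 values shown sit. So for compound 2 only a limit is known, and no measured step starts from it. Compound 4 `O=S(=O)(Nc1ccc(-c2nc3ccccc3o2)cc1)c1cccs1` differs from compound 2 by thiophen-2-yl in place of 4-methylphenyl on a sulfonyl sulfur. With nothing measured for this change, no step beyond the usual scatter is expected in this assay, in either direction, and compound 4 is expected most likely to remain at a limit as well. Compound 4 is estimated at 150000 nM, within 30000 nM to 1000000 nM. This estimate means an expected step that the limit leaves unreadable from compound 2 to compound 4.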

Compound 4, half-maximal inhibitory concentration: 63000 nM
Compound 4: the middle estimate sits 2.4-fold (0.38 log units) above what was measured, within the range that was stated.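

In this assay compound 4 gives 63000 nM as a measured number, so a group on the sulfonyl sulfur can be tied to a readable value. Compound 2 offers only a limit, not a number: the limit of > 100000 nM in this assay, at which 2 of the 4 values shown sit. Thiophen-2-yl in place of 4-methylphenyl therefore gives an at least 1.5-fold lower number from compound 2 to compound 4 (0.20 log units; that floor lies within the scatter) as a floor, and the true size of the step cannot be read.

From the compounds shown here alone, it remains open how a phenyl ring carrying a carboxylic acid or an amine would read on this sulfonyl sulfur. Going by these compounds, a longer carbon chain in this place is equally open.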